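Ester and acid on two related pyridine-bearing cores

The compounds below may be only part of what the source reports. "The series", "measured", "known", "first", "only" and "open" are said of these compounds alone.

This account concerns three compounds measured in an assay for inhibition of Fatty-acid amide hydrolase 1 (Rattus norvegicus) (on this read-out higher numbers stand for weaker inhibition and lower numbers for stronger inhibition), and one that has not yet been measured. Compound 1, `COC(=O)c1ccc(-c2cnc(C(=O)CCc3ccc(-c4ccccc4)cc3)o2)nc1`, gives 2.2 nM in this assay. Compound 2, `O=C(O)c1ccc(-c2cnc(C(=O)CCc3ccc(-c4ccccc4)cc3)o2)nc1`, gives 14 nM. Compound 3, `O=C(O)c1cccc(-c2cnc(C(=O)CCc3ccc(-c4ccc(CN5CCCCC5)cc4)cc3)o2)n1`, gives 44 nM and so stands highest of the three.

Compounds 2 and 1 differ in one place: methyl in place of hydrogen on an oxygen next to a carbonyl group. This change produced a 6.4-fold lower number from compound 2 to compound 1 (0.80 log units; beyond the scatter). Compound 4, `COC(=O)c1cccc(-c2cnc(C(=O)CCc3ccc(-c4ccc(CN5CCCCC5)cc4)cc3)o2)n1`, relates to compound 3 in the same way: methyl in place of hydrogen on an oxygen next to a carbonyl group. The place is worded identically in both pairs, so the change is the same one, made on a different core. Among the measured compounds shown here, the difference between the core of compound 2 and the core of compound 3 is not broken down here; what is seen is only that compound 3 gives a higher number than compound 2 in this assay, and compound 3 also carries a further substituent on its outer ring that compound 2 lacks.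

Because the step of a 6.4-fold lower number from compound 2 to compound 1 (0.80 log units; beyond the scatter) is beyond the scatter, a step of comparable direction and size is expected from compound 3 to compound 4, estimated as a 5.5-fold lower number from compound 3 to compound 4 (0.74 log units; beyond the scatter). The expectation is held somewhat loosely since the change is observed only once among the measured pairs and the cores differ. On that basis compound 4 is estimated to give 8 nM, expected to lie between 3 nM and 25 nM.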

Compound 4, inhibition constant: 9 nM
Beside the measured number, compound 4's estimate is 1.1-fold (0.05 log units) below it; measured number inside the range.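

In this assay, putting methoxycarbonyl in place of carboxy on the core of compound 3 gave a 4.9-fold lower number from compound 3 to compound 4 (0.69 log units; beyond the scatter), and set beside the earlier step the two agree: the same change on two cores in this assay, a 6.4-fold lower number (0.80 log units; beyond the scatter) from compound 2 to compound 1 and a 4.9-fold lower number (0.69 log units; beyond the scatter) from compound 3 to compound 4, 1.3-fold (0.11 log units) apart, within the scatter of two such steps. Within these two pairs, then, the change carries from one core to the other in both direction and size, and the methyl ester gives the lower number on each core, even though compound 3 and compound 4 also carry a further substituent on the outer ring that compound 2 and compound 1 lack. Among the compounds shown here, this is still only two pairs, so it shows no general rule for other cores and offers no explanation of why the methyl ester gives the lower number.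

The compounds shown leave open how much of the gap between the two cores comes from the further substituent on the outer ring and how much from the rest of the core, since no pair here differs in only one of these. They also leave open whether an ethyl ester, a longer chain on the same oxygen or an amide in place of the ester would follow the same course on either core.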